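The source may report more compounds than this note shows. Statements on the series, on what has been measured and on what is new or still open speak of the compounds shown alone.

Working notes on the series. In a physicochemical assay for lipophilicity, read by HPLC, at pH 7.4 (a lower number here means a more polar compound, a higher number a more lipophilic compound), compound 1 (`O=C(O)COc1ccc([C@H]2CC[C@]3(CC2)OOC2(O3)C3CC4CC(C3)CC2C4)cc1Cl`) gives 3.2 and compound 2 (`O=C(O)c1cc([C@H]2CC[C@]3(CC2)OOC2(O3)C3CC4CC(C3)CC2C4)ccc1O`) gives 3, two values within the scatter of each other. Both compounds carry a free carboxyl group.

Compound 3 (`CCOC(=O)COc1ccc([C@H]2CC[C@]3(CC2)OOC2(O3)C3CC4CC(C3)CC2C4)cc1`), an ethyl ester, reads > 5.3 in this assay. As far as these compounds go, that reading is a limit of the assay and not a number, so the true position of compound 3 remains open.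

The next entry is compound 4 (`CS(=O)(=O)NC(=O)COc1ccc([C@H]2CC[C@]3(CC2)OOC2(O3)C3CC4CC(C3)CC2C4)cc1`), which has methanesulfonamido in place of ethoxy on a carbonyl carbon. Going by the values given here, no measured step isolates this change, so its size has to be judged from the reference points available.

The working expectation is that compound 4 will read close to compound 1 at 3.2 and compound 2 at 3, rather than near the ester. A large downward move, well beyond the scatter, is therefore expected in this assay, with the estimated step being a number at least 2.30 log units lower from compound 3 to compound 4 (beyond the scatter). Since the starting point is only a limit, the size of that step is itself uncertain.

For compound 4 the estimated value is 3, with an expected range of 2.4 to 3.7.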

Compound 4, distribution coefficient: 3
Beside the measured number, compound 4's estimate shows no gap at the digits printed; low and high end bracket the measured number.
By their numbers in this assay, from the lowest: compounds 2, 4 and 1 (each within the scatter of the next). At a limit, above all of these: compound 3.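

In this assay, going by these compounds alone, methanesulfonamido in place of ethoxy on a carbonyl carbon gives the first readable step: a number at least 2.30 log units lower from compound 3 to compound 4 (beyond the scatter). Within the data shown here, this shows that the read-out responds strongly to a change at this one position, where the carbonyl carbon's other neighbour is a saturated chain carbon, something the earlier compounds, with no single-place step among them, could not show. The exact size of the step stays open because compound 3 stands at a limit of the assay and not at a number: the limit of > 5.3 in this assay, at which 1 of the 4 values shown sits.

The compounds shown leave open how a carboxylic acid, a primary amide or a longer sulfonamide such as ethanesulfonamido would read at this position with the rest of compound 4 unchanged, so the step cannot yet be divided between the loss of ethoxy and the entry of methanesulfonamido. As far as these compounds go, it also remains open whether the same exchange gives a step of similar size when the aromatic ring carries a chlorine, or when the ester partner has a shorter chain such as methoxy and reads as a number.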